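The source may hold more compounds than are shown below. What is called first, only, known or untested is meant among the compounds shown, and "the series" means these compounds.

Measured so far in an assay on isolated protein for displacement of a labelled ligand from metabotropic glutamate receptor 5 (Homo sapiens), with a stated time of 60 min, tested at 1 uM; a lower number here means less inhibition, a higher number more inhibition at the concentration tested (going by the name of the read-out):
- compound 1 `CC1CCN(c2c(S(=O)(=O)c3ccc(F)c(Cl)c3)cnc3cc(Cl)ccc23)CC1`: 94%
- compound 2 `CC1CCN(c2c(S(=O)(=O)c3ccc(F)c(Cl)c3)cnc3cc(F)ccc23)CC1`: 94%
- compound 3 `CC1CCN(c2c(S(=O)(=O)c3ccccc3)cnc3ccc(F)cc23)CC1`: 40%

Compound 2 stands level with compound 1 at the digits shown, and the two together give the highest numbers of the three; compound 3 gives a much lower number, beyond the scatter. The step to compound 4 `CC1CCN(c2c(S(=O)(=O)c3cc(F)cc(F)c3)cnc3cc(F)ccc23)CC1` is 3,5-difluorophenyl in place of 3-chloro-4-fluorophenyl on a sulfonyl sulfur. For the measured compounds named here, the only measured step that touches a halogen swap, no change at the digits printed from compound 1 to compound 2 (within the scatter), sits on the shared core rather than on the sulfonyl phenyl ring, so it bears only loosely here. Going by the values given here, no measured pair isolates a change on the sulfonyl phenyl ring alone. A small loss or no change beyond the scatter is therefore expected, a number 12 percentage points lower from compound 2 to compound 4 (beyond the scatter). Compound 4 is expected to give 82%, between 55% and 97%.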

Compound 4, a percentage reported as inhibition, at one concentration (the size of the read-out at that concentration, not a potency): 77%
The estimate for compound 4 lay 5 percentage points above the measured number; the range from low to high includes it.
By their numbers in this assay, from the lowest: compound 3; then compound 4; then compounds 1 and 2 (each within the scatter of the next).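

For the compounds shown here, this is the first step in which only the ring on the sulfonyl sulfur changes, and in this assay it gives a number 17 percentage points lower from compound 2 to compound 4 (beyond the scatter). The ring at this place therefore affects the read-out, whereas the halogen swap on the shared core gave no change at the digits printed from compound 1 to compound 2 (within the scatter). No available evidence accounts for the drop.

The change removes chlorine and rearranges fluorine in one step, so the compounds shown cannot separate these two effects. Going by these compounds, it also remains open how this place would respond to a nitrile, a methoxy group or an amine on the ring.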